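From benzyl to ethyl on a shared core

The source may hold more compounds than are shown below. What is called first, only, known or untested is meant among the compounds shown, and "the series" means these compounds.

Compound 1 `Cc1cc(=O)c2ccc(O)c(CN(Cc3ccccc3)Cc3ccccc3)c2o1`: 11.3 ug/mL
Compound 2 `COc1ccc(CN(Cc2ccccc2)Cc2c(O)ccc3c(=O)cc(C)oc23)cc1`: 10.7 ug/mL

In a functional assay on HCT-15 cells (Homo sapiens) for inhibition, read by sulforhodamine B assay, with a stated time of 72 h (on this read-out higher numbers stand for weaker inhibition and lower numbers for stronger inhibition), compound 2 gives 10.7 ug/mL, level with compound 1 within the scatter. Compound 3 `CCN(Cc1ccc(OC)cc1)Cc1c(O)ccc2c(=O)cc(C)oc12` differs from compound 2 in one place: methyl in place of phenyl on a saturated chain carbon bound to an amine nitrogen. Within the data shown here, the only measured step, a 1.1-fold lower number from compound 1 to compound 2 (0.02 log units; within the scatter), concerns a different change, methoxy in place of hydrogen, and offers no direct precedent. Only a small move to a higher number is therefore expected, not clearly beyond the scatter. The expected step is a 1.4-fold higher number from compound 2 to compound 3 (0.15 log units; within the scatter). Compound 3 is estimated at 15 ug/mL, with an expected range from 7 ug/mL to 35 ug/mL.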

Compound 3, half-maximal inhibitory concentration: 22.5 ug/mL
The estimate for compound 3 lay 1.5-fold (0.18 log units) below the measured number; low and high end bracket the measured number.
By their numbers in this assay, from the lowest: compounds 2, 1 and 3 (each within the scatter of the next, the first and the last beyond it).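

Swapping benzyl for ethyl, methyl in place of phenyl on a saturated chain carbon bound to an amine nitrogen, gives a 2.1-fold higher number from compound 2 to compound 3 (0.32 log units; beyond the scatter) in this assay and so moves the number beyond the scatter, which the methoxy change, a 1.1-fold lower number from compound 1 to compound 2 (0.02 log units; within the scatter), did not do. This position therefore responds to the loss of the phenyl ring, though only modestly. No available evidence accounts for the step. From the compounds shown here alone, whether the ring itself or simply the chain length matters remains open, and a propyl chain or a cyclohexylmethyl group in place of the ethyl could separate the two.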